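Cyclopropane Acid in Place of Acrylic Acid

This account rests on a few compounds, and the source may have more. Where it says the series, first, only, none or still open, it means among the compounds named here.

Compound 2 `O=C(O)/C=C/c1ccc(NCc2cccc(Oc3ccccc3)c2)cc1` gives 145 nM in a functional assay on CHO cells for agonist activity at Free fatty acid receptor 1 (Homo sapiens) (on this read-out lower numbers stand for an effect already at smaller amounts and higher numbers for an effect only at larger amounts of compound), the higher of the two numbers shown. Compound 3 `Cc1nc(-c2ccc(C(F)(F)F)cc2)sc1CNc1ccc(C(C)CC(=O)O)cc1` gives 58.9 nM in this assay, a gap beyond the scatter. Compound 1 `Cc1nc(-c2ccc(C(F)(F)F)cc2)sc1CNc1ccc(CCCC(=O)O)cc1` reaches only the limit < 10000 nM in this assay, not a number. The step from compound 1 to compound 3, a step that the limit leaves unreadable from compound 1 to compound 3, therefore cannot be sized (the limit of < 10000 nM in this assay, at which 1 of the 3 values shown sits). Compound 4 `O=C(O)[C@@H]1C[C@H]1c1ccc(NCc2cccc(Oc3ccccc3)c2)cc1` differs from compound 2 by 2-carboxycyclopropyl in place of 2-carboxyethenyl on an aromatic carbon. Among the compounds with values here, no measured step touches this change: the only computed step swaps other acid chains on the other core. The step of a 1.0-fold higher number from compound 2 to compound 4 (0.01 log units; within the scatter) is therefore estimated as none beyond the scatter. Compound 4 is expected to give 150 nM in this assay, within 45 nM to 500 nM.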

Compound 4, half-maximal effective concentration: 562 nM
Beside the measured number, compound 4's estimate is 3.7-fold (0.57 log units) below it; the whole stated range lies below it.
By their numbers in this assay, from the lowest: compound 3; then compound 2; then compound 4.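

Within the data shown here, putting 2-carboxycyclopropyl in place of 2-carboxyethenyl, para to a large group, gives the only readable step at this position in this assay: a 3.9-fold higher number from compound 2 to compound 4 (0.59 log units; beyond the scatter). The acid chain here therefore matters on this core, even though the two chains have the same counts of hydrogen-bond donors and acceptors. Nothing measured here says what lies behind this step.

Open, on these data alone, is whether a plain 2-carboxyethyl chain, with neither the double bond nor the three-membered ring, would give a number nearer that of compound 2 or compound 4. Also open, as far as these compounds go, is whether the same swap would have a similar effect on the core of compound 3.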